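The compounds below may be only part of what the source reports. "The series", "measured", "known", "first", "only" and "open" are said of these compounds alone.

Measured compounds:
- compound 1, `COc1ccc2c(=O)c(/C=C/C(=O)NCc3ccccc3F)coc2c1`: 146000 nM
- compound 2, `COc1cccc(NC(=O)/C=C/c2coc3cc(OC)ccc3c2=O)c1`: 1130000 nM
- compound 3, `COc1ccc2c(=O)c(/C=C/C(=O)Nc3cccc(C)c3)coc2c1`: 554000 nM

The three compounds share one core and differ only in the group on the amide-type nitrogen. In an ADME assay on HepG2 2.2.15 cells (Homo sapiens) for cytotoxicity, read by MTT assay, with stated times of 48 h and 9 days (on this read-out higher numbers stand for lower toxicity in this test and lower numbers for higher toxicity in this test), compound 1 gives 146000 nM, compound 2 gives 1130000 nM and compound 3 gives 554000 nM. Compound 3 stands second highest of the three; it lies a 2.0-fold lower number from compound 2 to compound 3 (0.31 log units; beyond the scatter) and a 3.8-fold higher number from compound 1 to compound 3 (0.58 log units; beyond the scatter).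

Compound 4, `COc1ccc2c(=O)c(/C=C/C(=O)Nc3ccc(F)cc3)coc2c1`, has not yet been measured in this assay. Its difference from compound 3 is 4-fluorophenyl in place of 3-methylphenyl on an amide-type nitrogen. For the measured compounds named here, no measured step exchanges one substituent on a phenyl ring for a fluorine, so the closest comparison is a 2.0-fold lower number from compound 2 to compound 3 (0.31 log units; beyond the scatter), a modest step between two substituted phenyl groups, while a 3.8-fold higher number from compound 1 to compound 3 (0.58 log units; beyond the scatter) shows a larger shift when the benzyl group gives way to a phenyl. The change to compound 4 keeps the phenyl, so a small step in this assay is expected, in either direction or none beyond the scatter. The estimate for compound 4 is therefore 500000 nM, with a range from 200000 nM to 1200000 nM, which means an expected step of a 1.1-fold lower number from compound 3 to compound 4 (0.04 log units; within the scatter).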

Compound 4, half-maximal cytotoxic concentration: 743000 nM
Compound 4: middle estimate off by 1.5-fold (0.17 log units), on the low side; measured number inside the range.
By their numbers in this assay, from the lowest: compound 1; then compounds 3, 4 and 2 (each within the scatter of the next, the first and the last beyond it).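

In this assay, 4-fluorophenyl on the amide-type nitrogen gives a 1.3-fold higher number from compound 3 to compound 4 (0.13 log units; within the scatter) when it replaces 3-methylphenyl and a 1.5-fold lower number from compound 2 to compound 4 (0.18 log units; within the scatter) when it replaces 3-methoxyphenyl, so compound 4 cannot be separated from either, even though a 2.0-fold lower number from compound 2 to compound 3 (0.31 log units; beyond the scatter) just clears the scatter. Compound 4 also carries fluorine, as compound 1 does, yet a 5.1-fold higher number from compound 1 to compound 4 (0.71 log units; beyond the scatter) places it with the other phenyl amides, so among these four compounds the lowest number, that of compound 1, goes with the 2-fluorobenzyl group rather than with the mere presence of fluorine, although that step changes the fluorine's ring position as well as the group that carries it. No supporting data bear on why these groups give these numbers.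

Compound 1 is the only benzyl compound shown. A plain benzyl group would be needed to separate the effect of the added carbon from that of its fluorine. The compounds shown also leave open how a phenyl ring carrying an amine or a carboxylic acid would behave, and whether a longer chain between the nitrogen and the ring would lower the number further.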